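Removing the Hydroxy Group from a Cyclohexyl Alkyne

The source may hold more compounds than are shown below. What is called first, only, known or untested is meant among the compounds shown, and "the series" means these compounds.

Compound 1 `C/C=C(/C)C#Cc1ccc(CCC(=O)O)c(F)c1` gives 20.4 nM; 20 nM (2 entries) in a functional assay on 1321-N1 cells for agonist activity at Free fatty acid receptor 1 (Homo sapiens), read by calcium flux, with a stated time of 0.4 s; a lower number here means that less compound is needed, a higher number that more compound is needed for the effect. Compound 2 `O=C(O)CCc1ccc(C#CC2(O)CCCCC2)cc1` stands differently: in this assay it has only a limit, < 100000 nM, which is a boundary of the measurement and not a number. Compound 3 `O=C(O)CCc1ccc(C#CC2CCCCC2)cc1` differs from compound 2 by hydrogen in place of hydroxy on a saturated ring carbon. Among the compounds with values here, no measured pair shows this change, so the direction of the step in this assay is open; a step of modest size in either direction seems as plausible as none beyond the scatter. Compound 3 is expected to give 5000 nM, within 800 nM to 40000 nM. The expected step is a step that the limit leaves unreadable from compound 2 to compound 3.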

Compound 3, half-maximal effective concentration: 513 nM
Estimate against measurement, compound 3: 9.7-fold (0.99 log units) above, and the stated range ends above it.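

In this assay, within the data shown here, no step from compound 2 to compound 3 can be read. Compound 2 gives < 100000 nM, which is a limit and not a number. The compounds shown leave open how large the effect of hydrogen in place of hydroxy is.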